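The source may hold more compounds than are shown below. What is called first, only, known or untested is meant among the compounds shown, and "the series" means these compounds.

Compound 1 `Cc1c2c(n3c1CCN(C)C[C@@H](C)[C@H](C)Nc1cc-3ccc1C(N)=O)CC(C)(C)CC2=O` gives 27 nM in a functional assay on HCT-116 cells (Homo sapiens) for antiproliferative activity; a higher number here means a weaker inhibitor, a lower number a stronger inhibitor.
Compound 2 `COCCC(=O)N1CCc2c(C)c3c(n2-c2ccc(C(N)=O)c(c2)N[C@@H](C)[C@H](C)C1)CC(C)(C)CC3=O` gives 38 nM in this assay.

For the measured compounds named here, compound 2 stands alongside compound 1 in this assay: the one measured step, a 1.4-fold higher number from compound 1 to compound 2 (0.15 log units; within the scatter), lies within the scatter, so the two numbers cannot be told apart. Compound 3 `Cc1c2c(n3c1CCN(C(=O)[C@H](C)O)C[C@@H](C)[C@H](C)Nc1cc-3ccc1C(N)=O)CC(C)(C)CC2=O` has not yet been measured. It differs from compound 2 by 1-hydroxyethyl in place of 2-methoxyethyl on a carbonyl carbon. Going by the values given here, only the step from compound 1 to compound 2 touches the same position, and it shows that exchanging a methyl for a (2-methoxyethyl)carbonyl on that ring nitrogen left this assay unchanged beyond the scatter. A swap of one small acyl group for another at the same place is therefore expected to produce no step beyond the scatter, in either direction, so no change at the digits printed from compound 2 to compound 3 (within the scatter) is the expected change. Compound 3 is thus estimated at 38 nM, with a range from 18 nM to 80 nM.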

Compound 3, half-maximal inhibitory concentration: 42 nM
Compound 3: middle estimate off by 1.1-fold (0.04 log units), on the low side; the range from low to high includes it.
By their numbers in this assay, from the lowest: compounds 1, 2 and 3 (each within the scatter of the next).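

With a second acyl group on the ring nitrogen, the result shows that what was seen earlier does not depend on the 2-methoxyethyl side chain: in this assay, 1-hydroxyethyl on the carbonyl carbon brings a hydrogen-bond donor and a defined stereocentre, yet the swap gives a 1.1-fold higher number from compound 2 to compound 3 (0.04 log units; within the scatter). The (1-hydroxyethyl)carbonyl group in place of methyl on the amine nitrogen gives a 1.6-fold higher number from compound 1 to compound 3 (0.19 log units; within the scatter), so methyl and both acyl groups cannot be told apart at this position. Nothing available bears on why these numbers agree.

On these data alone, it remains open whether an amine, a carboxylic acid or a longer chain on that carbonyl carbon would also leave this assay within the scatter. The compounds shown also leave open whether the opposite configuration at the 1-hydroxyethyl stereocentre would read the same.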